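Coumarin-bearing pyrazolone amines: aryl swap at the amine nitrogen

The source may report more compounds than this note shows. Statements on the series, on what has been measured and on what is new or still open speak of the compounds shown alone.

Compound 1 `CC1=NN(C(=O)c2cc3ccccc3oc2=O)C(=O)C1CNc1cccc(S(N)(=O)=O)c1` is the reference of this pair. In a functional assay on the whole organism for inhibition, with Rattus norvegicus as the target, read by paw edema, with stated times of 1 h and 4 h, at a dose of 0.03 mg/kg by the oral route (on this read-out higher numbers stand for more inhibition at the one dose given (going by the name of the read-out) and lower numbers for less inhibition), compound 1 gives 67.8%, the higher of the two numbers measured. Going by the values given here, compound 2 `CC1=NN(C(=O)c2cc3ccccc3oc2=O)C(=O)C1CNc1ccc(Cl)cc1` gives 43.5%, and the step of a number 24.3 percentage points lower from compound 1 to compound 2 (beyond the scatter) is the only measured change at the amine nitrogen; it also removes the 3-sulfamoylphenyl of compound 1.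

Compound 3 `CC1=NN(C(=O)c2cc3ccccc3oc2=O)C(=O)C1CNc1ccc(O)c(C(=O)O)c1` has not yet been measured. It differs from compound 1 as follows: 3-carboxy-4-hydroxyphenyl in place of 3-sulfamoylphenyl on an amine nitrogen. Among the compounds with values here, no measured step replaces this group with another bearing two hydrogen-bond donors and two acceptors, so the one step from compound 1 to compound 2 is only a loose guide. A smaller loss than that step, possibly none beyond the scatter, is expected for compound 3, namely a number 12.8 percentage points lower from compound 1 to compound 3 (beyond the scatter). Compound 3 is therefore estimated at 55%, within the range 35% to 72%.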

Compound 3, a percentage reported as inhibition, in the whole organism at one dose (the size of the read-out at that dose, not a potency): 30.9%
The estimate for compound 3 lay 24.1 percentage points above the measured number, and the stated range ends above it.
By their numbers in this assay, from the lowest: compound 3; then compound 2; then compound 1.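

In this assay, the step of a number 36.9 percentage points lower from compound 1 to compound 3 (beyond the scatter) shows that 3-carboxy-4-hydroxyphenyl on the amine nitrogen does not hold the level of 3-sulfamoylphenyl, although both groups have the same counts of heavy atoms and hydrogen-bond acceptors. The step of a number 12.6 percentage points lower from compound 2 to compound 3 (beyond the scatter) places it under 4-chlorophenyl as well, so both replacements of 3-sulfamoylphenyl lose inhibition at this position, and the one with the added hydrogen-bond donor loses more. No measurement is available that explains this order.

The three compounds do not separate the contribution of the carboxylic acid from that of the hydroxyl. Going by these compounds, it also remains open how a plain phenyl, or a phenyl carrying only a carboxylic acid or a methanesulfonyl group, would compare with 3-sulfamoylphenyl.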